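Cyclopropyl in place of propenyl on the amide carbonyl

The source may report more compounds than this note shows. Statements on the series, on what has been measured and on what is new or still open speak of the compounds shown alone.

Within the data shown here, compound 2 `C/C=C/C(=O)Nc1c(C(O)(C(F)(F)F)C(F)(F)F)ccc2ccccc12` is one of two compounds measured in a functional assay (Sus scrofa) with sulfonylurea receptors; K-ATP channels (Homo sapiens) as the target (on this read-out lower numbers stand for smaller maximal responses and higher numbers for larger maximal responses), where compound 2 gives 96%. Compound 1 `CCCC(=O)Nc1c(C(O)(C(F)(F)F)C(F)(F)F)ccc2ccccc12` gives 92% in this assay, and the step of a number 4 percentage points higher from compound 1 to compound 2 (within the scatter) shows the two numbers within the usual scatter of each other. Compound 3 `O=C(Nc1c(C(O)(C(F)(F)F)C(F)(F)F)ccc2ccccc12)C1CC1` has not yet been measured; it differs from compound 2 by cyclopropyl in place of prop-1-en-1-yl on a carbonyl carbon. Among the measured compounds shown here, the only measured step, from compound 1 to compound 2, stayed within the scatter, so no step beyond the scatter is expected here. For compound 3 the estimate in this assay is 94%, ranging from 82% to 104%. This expectation means a step of a number 2 percentage points lower from compound 2 to compound 3 (within the scatter).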

Compound 3, largest response reached (reported as efficacy), in percent of the reference or control that the assay uses: 100%
Estimate against measurement, compound 3: 6 percentage points below, within the range that was stated.
By their numbers in this assay, from the lowest: compounds 1, 2 and 3 (each within the scatter of the next).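

In this assay the cyclopropyl ring on the carbonyl carbon gives a number 4 percentage points higher from compound 2 to compound 3 (within the scatter) and also a number 8 percentage points higher from compound 1 to compound 3 (within the scatter). Propyl, prop-1-en-1-yl and cyclopropyl thus all sit within the scatter of one another, so at this position a three-membered ring reads the same as either open chain. Nothing available explains this sameness. From the compounds shown here alone, whether a larger ring such as cyclohexyl, a phenyl group or a chain ending in an amine on this carbonyl carbon would move the number beyond the scatter stays open.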